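Chloro for hydrogen on the aryl ring of compound 3

The compounds below may be only part of what the source reports. "The series", "measured", "known", "first", "only" and "open" are said of these compounds alone.

Compound 3 `Nc1scc(CN2CCN(c3cccc(C(F)(F)F)c3)CC2)c1C(=O)c1ccc(Cl)cc1` stands lowest of the three compounds measured in a functional assay on CHO cells with adenosine receptor A1 (Homo sapiens) as the target, read by cAMP accumulation and immunoassay, with a stated time of 6 min, tested at 0.01 uM (a lower number here means a stronger effect, a higher number a weaker effect of the compound at the concentration tested), with compound 3 giving -8.2%. Compound 1 `Nc1scc(CN2CCN(c3ccc(Cl)cc3Cl)CC2)c1C(=O)c1ccc(Cl)cc1` gives 2% and compound 2 `Nc1scc(CN2CCN(c3cccc(Cl)c3Cl)CC2)c1C(=O)c1ccc(Cl)cc1` gives 1%. The two steps that reach compound 3 each exchange the whole group on the amine nitrogen in the ring: a number 10.2 percentage points lower from compound 1 to compound 3 (beyond the scatter) and a number 9.2 percentage points lower from compound 2 to compound 3 (within the scatter). Compound 4 `Nc1scc(CN2CCN(c3ccc(Cl)c(C(F)(F)F)c3)CC2)c1C(=O)c1ccc(Cl)cc1` differs from compound 3 by chloro in place of hydrogen on an aromatic carbon, ortho to a trifluoromethyl group. Among the measured compounds shown here, no measured step adds a chloro group to an aromatic carbon, so the change is not directly covered; the two steps that do bear on it, each of about the size of the scatter, point to no movement beyond it in this assay. Compound 4 is therefore expected to show a number 2.2 percentage points higher from compound 3 to compound 4 (within the scatter), giving an estimated -6% with a range of -22% to 10%.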

Compound 4, a percentage reported as activity, at one concentration (the size of the read-out at that concentration, not a potency): -2.5%
Compound 4: the middle estimate sits 3.5 percentage points below what was measured, within the range that was stated.
By their numbers in this assay, from the lowest: compounds 3, 4, 2 and 1 (each within the scatter of the next, the first and the last beyond it).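

In this assay, among the compounds shown here, chloro in place of hydrogen on the aromatic carbon ortho to a trifluoromethyl group gives a number 5.7 percentage points higher from compound 3 to compound 4 (within the scatter) as the first direct reading of this change at this position. The 4-chloro-3-(trifluoromethyl)phenyl group also stays close to both dichlorophenyl groups, with a number 3.5 percentage points lower from compound 2 to compound 4 (within the scatter) and a number 4.5 percentage points lower from compound 1 to compound 4 (within the scatter) on the same shared core. Nothing available explains these readings.
Still open, from the compounds shown here alone, is whether a methoxy group or an amine on that same aromatic carbon would move the number beyond the scatter.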